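Cytotoxicity notes on a nitro-trifluoromethyl series

The compounds below may be only part of what the source reports. "The series", "measured", "known", "first", "only" and "open" are said of these compounds alone.

Measured compounds:
compound 1 `O=C(c1ccc(Cl)cc1)N1CCN(c2nc(=O)c3cc(C(F)(F)F)cc([N+](=O)[O-])c3s2)CC1`: > 125000 nM
compound 2 `O=c1nc(N2CCN(CC3CCCCC3)CC2)sc2c([N+](=O)[O-])cc(C(F)(F)F)cc12`: > 125000 nM
compound 3 `CC1COC2(CCN(c3nc(=O)c4cc(C(F)(F)F)cc([N+](=O)[O-])c4s3)CC2)O1`: > 125000 nM

All three values in an ADME assay on Vero cells (Chlorocebus sabaeus) for cytotoxicity, read by MTT assay, with a stated time of 72 h (on this read-out higher numbers stand for lower toxicity in this test and lower numbers for higher toxicity in this test), are limits of the assay rather than numbers. Compound 1 gives > 125000 nM, a limit. Compound 2 gives > 125000 nM, also a limit. Compound 3 gives > 125000 nM, again a limit. Among the measured compounds shown here, the one step among them, a step that the two limits leave unreadable from compound 1 to compound 2, cannot be read because both of its ends sit at the limit. Compound 2 therefore stands where every compound in this set stands, at the limit of the assay, with no ordering possible among the three.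

The next compound, compound 4 `O=C(c1ccc(F)cc1)N1CCN(c2nc(=O)c3cc(C(F)(F)F)cc([N+](=O)[O-])c3s2)CC1`, differs from compound 2 by (4-fluorophenyl)carbonyl in place of cyclohexylmethyl on an amine nitrogen in a ring. Compound 4 shares with compound 1 an arylcarbonyl on the amine nitrogen, and compound 1 sits at the same limit as compound 2, so neither measured value points away from the limit. For the measured compounds named here, the only bearing evidence is the limit of > 125000 nM in this assay, at which 3 of the 3 values shown sit, at which all values shown sit. Going by the values given here, no step of readable size exists, so no shift beyond the scatter is expected in this assay.

The expected result for compound 4 is 150000 nM, within 100000 nM to 300000 nM, and the estimated step that the limit leaves unreadable from compound 2 to compound 4 is expected to be unreadable at the limit.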

Compound 4, half-maximal cytotoxic concentration: > 125000 nM
Compound 4: a limit, no number; the forecaster's own chance of this, stated with the estimate: 85%; the middle value is on the limit's open side.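

Neither the step from compound 2 to compound 4 nor the step from compound 1 to compound 4 can be read: both ends of each are limits, not numbers. The compounds shown leave open whether swapping the group on the ring amine nitrogen, or fluoro for chloro, changes the result in this assay at all: the limit of > 125000 nM in this assay, at which 4 of the 4 values shown sit.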